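A nitro group in place of hydroxy on compound 1

The source may hold more compounds than are shown below. What is called first, only, known or untested is meant among the compounds shown, and "the series" means these compounds.

Compound 1 `CC1=CC[C@H](C(C)(C)NC(=S)N/N=C/c2ccccc2O)CC1` was measured in a functional assay on NCI-H460 cells (Homo sapiens) for inhibition, read by sulforhodamine B assay, with a stated time of 48 h (on this read-out higher numbers stand for weaker inhibition of growth and lower numbers for stronger inhibition of growth), where compound 1 gives 1900 nM. Of the two numbers recorded so far this is the higher one; the nearest neighbour is compound 2 `CC1=CC[C@H](C(C)(C)NC(=S)N/N=C/c2cccc(Cl)c2)CC1`, which in this assay gives 1400 nM. Among the measured compounds shown here, the one step between measured compounds, a 1.4-fold lower number from compound 1 to compound 2 (0.13 log units; within the scatter), exchanges one aromatic substituent for another and stays within the scatter, so a change of the group on the aromatic ring of this part of the molecule has so far left the growth inhibition essentially unchanged.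

Compound 3 `CC1=CC[C@H](C(C)(C)NC(=S)N/N=C/c2ccccc2[N+](=O)[O-])CC1` carries the same core as compound 1 and differs from it by nitro in place of hydroxy on an aromatic carbon, a nitro in place of hydroxy on an aromatic carbon, ortho to a large group. For the measured compounds named here, the only step that bears on this change is the substituent exchange from compound 1 to compound 2, which was small. On that basis no step beyond the scatter is expected in this assay, and the step of no change at the digits printed from compound 1 to compound 3 (within the scatter) is the estimated outcome. For compound 3 the expected value in this assay is 1900 nM, with a range from 700 nM to 5000 nM.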

Compound 3, concentration for 50% growth inhibition: 5000 nM
The estimate for compound 3 lay 2.6-fold (0.42 log units) below the measured number, within the range that was stated.
By their numbers in this assay, from the lowest: compounds 2 and 1 (each within the scatter of the next); then compound 3.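

In this assay, among the compounds shown here, the change from hydroxy to nitro on this aromatic carbon, ortho to a large group, gives a 2.6-fold higher number from compound 1 to compound 3 (0.42 log units; beyond the scatter) and is the first step to pass beyond the scatter, so here the number moves towards weaker inhibition of growth. The group at this place can therefore alter the read-out, which the earlier step, 3-chlorophenyl in place of 2-hydroxyphenyl, did not show, and the size of the step remains modest. Hydroxy, with 1 hydrogen-bond donor and 1 heavy atom, leaves and nitro, with 0 hydrogen-bond donors and 3 heavy atoms, enters, but nothing measured here ties the step to either of these differences or to any other property of the two groups.

The compounds shown leave open whether an amine, a methoxy group or a carboxylic acid on this same carbon would give a number close to that of hydroxy or close to that of nitro. They also leave open whether nitro on another carbon of the aromatic ring would give the same step, since only this one place has been compared for this exchange.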